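From naphthalen-2-yl to 4-chlorophenyl: compound 3 awaits measurement

The source may hold more compounds than are shown below. What is called first, only, known or untested is meant among the compounds shown, and "the series" means these compounds.

In an in vivo ADME assay on the whole organism (Cavia porcellus) (a higher number here means that the compound lasts longer, a lower number that the compound disappears faster), compound 2 `CC(C)(C(=O)N1CCC(CC(=O)O)CC1)C(NC(=O)c1ccc(C(=N)N)cc1)c1ccc2ccccc2c1` gives 0.85 h and compound 1 `CCCCC(NC(=O)c1ccc(C(=N)N)cc1)C(C)(C)C(=O)N1CCC(CC(=O)O)CC1` gives 1.03 h as its half-life, two numbers within the scatter of each other. Compound 3 `CC(C)(C(=O)N1CCC(CC(=O)O)CC1)C(NC(=O)c1ccc(C(=N)N)cc1)c1ccc(Cl)cc1` differs from compound 2 by 4-chlorophenyl in place of naphthalen-2-yl on a saturated chain carbon bound to an amide-type nitrogen and a saturated chain carbon and keeps the rest of the structure: 4-chlorophenyl stands in place of naphthalen-2-yl on a saturated chain carbon bound to an amide-type nitrogen and a saturated chain carbon. For the measured compounds named here, the one measured step at this carbon, from butyl to naphthalen-2-yl, is a 1.2-fold lower number from compound 1 to compound 2 (0.08 log units; within the scatter) and stays within the scatter, so no step beyond the scatter is expected in this assay for this exchange either. The expected step is a 1.1-fold higher number from compound 2 to compound 3 (0.05 log units; within the scatter) and is estimated to remain within the scatter. For compound 3 the estimate is 0.95 h with an expected range from 0.6 h to 1.5 h in this measurement.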

Compound 3, half-life: 1.2 h
Compound 3: the middle estimate sits 1.3-fold (0.10 log units) below what was measured; low and high end bracket the measured number.
By their numbers in this assay, from the lowest: compounds 2, 1 and 3 (each within the scatter of the next).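

In this assay, the saturated chain carbon bound to an amide-type nitrogen and a saturated chain carbon now carries a third group, and both new exchanges stay within the scatter: 4-chlorophenyl in place of naphthalen-2-yl gives (a 1.4-fold higher number from compound 2 to compound 3 (0.15 log units; within the scatter)), and 4-chlorophenyl in place of butyl gives (a 1.2-fold higher number from compound 1 to compound 3 (0.07 log units; within the scatter)). The earlier pair compared only a chain with two aromatic rings, whereas a single chlorine-bearing ring now also leaves the half-life unresolved from both, so across these three compounds the half-life does not separate by the group at this carbon. No evidence on the cause is at hand.

From the compounds shown here alone, whether an amine or a hydroxyl group on this carbon would carry the half-life beyond the scatter stays open. All three compounds share the rest of the core, so they do not show how the half-life responds to a change elsewhere.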